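This account rests on a few compounds, and the source may have more. Where it says the series, first, only, none or still open, it means among the compounds named here.

Working notes on the series. Three compounds have readings in a functional assay on the whole organism (strain Wistar Albino) for inhibition, with Rattus norvegicus as the target, read by paw edema, with a stated time of 1 h, at a dose of 20 mg/kg; on this read-out higher numbers stand for more inhibition at the one dose given (going by the name of the read-out) and lower numbers for less inhibition. Compound 1 `COc1ccc(Cc2nnc3sc(-c4ccnc(Cl)c4)nn23)cc1OC` gives 11.2% in this assay. Compound 2 `COc1ccc2[nH]c(C)c(Cc3nn4c(Cc5ccc(OC)c(OC)c5)nnc4s3)c2c1` gives 10.5% in this assay. Compound 3 `COc1ccc(Cc2nnc3n2NC(c2ccco2)S3)cc1OC` gives 12% in this assay; its reported number is the highest of the three, yet the gap to compound 1 and the gap to compound 2 both lie within the scatter, so the three readings cannot be told apart. No two of these compounds differ in one place, so no single measured step is available.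

Compound 4 `COc1ccc(Cc2nnc3n2NC(c2ccc([N+](=O)[O-])o2)S3)cc1OC` has not been measured. It differs from compound 3 by nitro in place of hydrogen on an aromatic carbon. Among the measured compounds shown here, with no measured step to lean on, and with all three readings sitting together, the expected step of a number 2 percentage points higher from compound 3 to compound 4 (within the scatter) is none beyond the scatter. Compound 4 is accordingly estimated at 14% in this assay, with an expected range from 4% to 24%.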

Compound 4, a percentage reported as inhibition, in the whole organism at one dose (the size of the read-out at that dose, not a potency): 14.5%
Compound 4: middle estimate off by 0.5 percentage points, on the low side, within the range that was stated.
By their numbers in this assay, from the lowest: compounds 2, 1, 3 and 4 (each within the scatter of the next).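

The change from furan-2-yl to 5-nitrofuran-2-yl gives the series its first step in one place, and in this assay it reads a number 2.5 percentage points higher from compound 3 to compound 4 (within the scatter). The position next to the ring oxygen therefore carries nitro, with its 3 heavy atoms, while compound 4 remains indistinguishable from compound 3 on this read-out. Nothing measured here bears on the reason for this result.

Still open, on these data alone, is whether another group at this place, such as an amine or a carboxylic acid, would give a step beyond the scatter. The compounds shown also leave open whether nitro in place of hydrogen would read the same way with a different group on the rest of the shared core, since this single step comes from one pair.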